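The source may hold more compounds than are shown below. What is called first, only, known or untested is meant among the compounds shown, and "the series" means these compounds.

Working notes on the series. For the measured compounds named here, compound 2 `CCn1c(=O)/c(=C2\Sc3ccccc3N2C)s/c1=C\c1ccncc1Nc1ccccc1C` stands at the top of the three numbers so far in a functional assay on PC-3 cells (Homo sapiens) for inhibition; on this read-out higher numbers stand for weaker inhibition and lower numbers for stronger inhibition: compound 2 gives 1200 nM. Compound 3 `CCn1c(=O)/c(=C2\Sc3ccc(C)cc3N2C)s/c1=C\c1ccncc1Nc1ccccc1C` gives 330 nM, and compound 1 `CCn1c(=O)/c(=C2\Sc3cc(F)ccc3N2C)s/c1=C\c1ccncc1Nc1ccccc1F` gives 260 nM, which is the furthest of the set from compound 2. Compound 4 `CCn1c(=O)/c(=C2\Sc3cc(F)ccc3N2C)s/c1=C\c1ccncc1Nc1ccccc1C` is not yet measured. It differs from compound 2 in one place: fluoro in place of hydrogen on an aromatic carbon. Going by the values given here, the one measured step that bears directly on this is a 3.6-fold lower number from compound 2 to compound 3 (0.56 log units; beyond the scatter), a substituent entering an aromatic carbon of the same fused system, though there it was methyl rather than fluoro. Among the compounds with values here, compound 1 carries the same fluoro on the fused ring but differs from compound 2 elsewhere as well, so its number is only a loose pointer; no single-change step connects compound 1 to compound 2. Taken together, the step of a 2.7-fold lower number from compound 2 to compound 4 (0.43 log units; beyond the scatter) is expected to be a modest lowering, in the same direction as the methyl step but not assumed to match it exactly. Compound 4 is therefore estimated at 450 nM, with a range from 200 nM to 1000 nM.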

Compound 4, half-maximal inhibitory concentration: 2300 nM
The estimate for compound 4 lay 5.1-fold (0.71 log units) below the measured number, outside the stated range (above it).
By their numbers in this assay, from the lowest: compounds 1 and 3 (each within the scatter of the next); then compounds 2 and 4 (each within the scatter of the next).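

With fluoro on this aromatic carbon of the fused system, this assay shows a 1.9-fold higher number from compound 2 to compound 4 (0.28 log units; within the scatter), so this change cannot be told apart from no change, whereas the methyl step on the same fused system, a 3.6-fold lower number from compound 2 to compound 3 (0.56 log units; beyond the scatter), lies beyond the scatter; entry of a substituent into that ring therefore does not by itself lower the number. The larger difference among these pairs lies at the other aromatic carbon, where methyl in place of fluoro, with the fused-ring fluoro held constant, gives an 8.8-fold higher number from compound 1 to compound 4 (0.95 log units; beyond the scatter), so the low number seen with the fused-ring fluoro belongs to the pair carrying the second fluoro and not to the fused-ring fluoro alone. Nothing at hand gives a measured basis for either difference.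

The compounds shown leave open whether the methyl-for-fluoro step keeps its size when the fused ring carries hydrogen instead of fluoro. They also leave open whether a chloro, methoxy or amino group on the fused-ring carbon would move the number beyond the scatter from that of compound 2.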